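From furan-3-yl to thiophen-2-yl on a shared core

The source may report more compounds than this note shows. Statements on the series, on what has been measured and on what is new or still open speak of the compounds shown alone.

Three nucleosides have been tested in a functional assay on CEM-DNR-bulk cells (Homo sapiens), read by MTT assay, with a stated time of 72 h; a higher number here means a weaker inhibitor, a lower number a stronger inhibitor. Compound 1 `CN(C)c1ncnc2c1c(-c1cc3ccccc3o1)cn2[C@@H]1O[C@H](CO)[C@@H](O)[C@H]1O` returned only a limit, > 20000 nM. Compound 2 `Nc1nc2c(c(-c3ccco3)cn2[C@@H]2O[C@H](CO)[C@@H](O)[C@H]2O)c(=O)[nH]1` also returned only a limit, > 20000 nM. Within the data shown here, compound 3 `Nc1nc2c(c(-c3ccoc3)cn2[C@@H]2O[C@H](CO)[C@@H](O)[C@H]2O)c(=O)[nH]1` gave 15000 nM, the only actual number. Compound 1 and compound 2 share (the limit of > 20000 nM in this assay, at which 2 of the 3 values shown sit).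

Compound 4 `Nc1nc2c(c(-c3cccs3)cn2[C@@H]2O[C@H](CO)[C@@H](O)[C@H]2O)c(=O)[nH]1` keeps the core of compound 3 and carries thiophen-2-yl in place of furan-3-yl on an aromatic carbon of a five-membered aromatic ring with 1 nitrogen (thiophen-2-yl in place of furan-3-yl on an aromatic carbon). The closest evidence is the exchange of furan-2-yl for furan-3-yl at the same place, which gave an at least 1.3-fold lower number from compound 2 to compound 3 (0.12 log units; that floor lies within the scatter). That step is small and is bounded on one side only. Among the measured compounds shown here, no measured step exchanges a furan for a thiophene, and compound 1 differs from the others in more than this one group. The evidence therefore gives no reason to expect a clear shift in either direction. The expected result is no change at the digits printed from compound 3 to compound 4 (within the scatter), which is not expected to exceed the scatter. A result reported only as a limit would remain quite possible. For compound 4 the estimated value in this assay is 15000 nM, with an expected range from 5000 nM to 30000 nM.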

Compound 4, half-maximal inhibitory concentration: > 20000 nM
Compound 4 was reported as a limit; the forecaster's own chance of this, stated with the estimate: 45%; middle value at least 1.3-fold (0.12 log units) from the limit.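

In this assay compound 4 is reported only as a limit, > 20000 nM. From the compounds shown here alone, replacing furan-3-yl with thiophen-2-yl on this aromatic carbon gives an at least 1.3-fold higher number from compound 3 to compound 4 (0.12 log units; that floor lies within the scatter), so a sulfur-bearing five-membered ring now joins the two furans at this position, but the step has only a floor and its true size is unknown. The step from compound 2 to compound 4 joins two limits and cannot be read, and the series now gathers at a single limit: the limit of > 20000 nM in this assay, at which 3 of the 4 values shown sit.

Among these compounds, how far the true value of compound 4 lies from its limit remains open, as does whether any exchange at this position can move the number beyond the scatter, with compound 3 still the only compound here that has an actual number. Also open, going by these compounds, is how thiophen-3-yl, a plain phenyl ring, an amine or a carboxylic acid on this aromatic carbon of the shared core would read in this assay.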